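Changing one stereocentre: expected stability of compound 3

The compounds below may be only part of what the source reports. "The series", "measured", "known", "first", "only" and "open" are said of these compounds alone.

- compound 1 `O=[N+]([O-])c1cn2c(n1)[S@+]([O-])C[C@H](OCc1ccc(OC(F)(F)F)cc1)C2`: 88%
- compound 2 `O=[N+]([O-])c1cn2c(n1)[S@@+]([O-])C[C@@H](OCc1ccc(OC(F)(F)F)cc1)C2`: 93%

In an ADME assay on microsomes from liver (Homo sapiens) for metabolic stability, with a stated time of 1 h (on this read-out lower numbers stand for a less stable compound and higher numbers for a more stable compound), compound 2 gives 93%, level with compound 1 within the scatter. Compound 3 `O=[N+]([O-])c1cn2c(n1)[S@@+]([O-])C[C@H](OCc1ccc(OC(F)(F)F)cc1)C2` has the same atoms and bonds as compound 2: the two compounds have the same atoms and bonds and differ only in configuration as drawn: 1 of 2 stereo elements differ; a stereocentre at a saturated ring carbon is drawn S in compound 2 and R in compound 3. For the measured compounds named here, only one measured step bears on this change: a number 5 percentage points higher from compound 1 to compound 2 (within the scatter). That step inverted both stereocentres and stayed within the scatter, so no step beyond the scatter is expected in this assay for inverting one. The estimated step is a number 5 percentage points lower from compound 2 to compound 3 (within the scatter). For compound 3, the expected value is 88%, with an estimated range of 75% to 98%.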

Compound 3, percent of the compound remaining: 91%
Compound 3: the middle estimate sits 3 percentage points below what was measured; measured number inside the range.
By their numbers in this assay, from the lowest: compounds 1, 3 and 2 (each within the scatter of the next).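

Compound 3 pulls apart the two stereocentres, which compound 1 and compound 2 showed only as inverted together. In this assay, inverting the saturated ring carbon alone gives a number 2 percentage points lower from compound 2 to compound 3 (within the scatter), and inverting the sulfur alone gives a number 3 percentage points higher from compound 1 to compound 3 (within the scatter). Each centre has now been turned on its own, and neither turn takes the number beyond the scatter.

Going by these compounds, whether configuration matters as little with a different side chain on the shared core, such as one carrying an amine or a carboxylic acid, stays open. These compounds also say nothing about configuration in any other read-out.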